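The source may hold more compounds than are shown below. What is called first, only, known or untested is meant among the compounds shown, and "the series" means these compounds.

In a functional assay on HeLa cells (Homo sapiens) for antiproliferative activity, read by MTT assay, with a stated time of 72 h (on this read-out higher numbers stand for weaker inhibition and lower numbers for stronger inhibition), compound 1 `C/C(C#Cc1ccccc1)=N\N/C(N)=N/S(=O)(=O)c1cc(C)c(Cl)cc1SCc1ccccc1C` gives 270000 nM. Compound 2 `C/C(C#Cc1ccccc1)=N\N/C(N)=N/S(=O)(=O)c1cc(C)c(Cl)cc1SCc1ccc(C)cc1` gives 110000 nM in this assay, and compound 3 `C/C(C#Cc1ccccc1)=N\N/C(N)=N/S(=O)(=O)c1cc(C)c(Cl)cc1SCc1cccc(C(F)(F)F)c1` gives 18000 nM. Compound 3 holds the lowest number of the three: the step of a 15-fold lower number from compound 1 to compound 3 (1.18 log units; beyond the scatter) is large, the step of a 6.1-fold lower number from compound 2 to compound 3 (0.79 log units; beyond the scatter) is modest, and both lie beyond the scatter, as does the step of a 2.5-fold lower number from compound 1 to compound 2 (0.39 log units; beyond the scatter) between the two methylphenyl analogues.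

Compound 4 `C/C(C#Cc1ccccc1)=N\N/C(N)=N/S(=O)(=O)c1cc(C)c(Cl)cc1SCc1cccc(Cl)c1` differs from compound 3 by chloro in place of trifluoromethyl on an aromatic carbon. For the measured compounds named here, no measured step exchanges these two groups. Going by the values given here, the steps that bear on this place, a 15-fold lower number from compound 1 to compound 3 (1.18 log units; beyond the scatter) and a 6.1-fold lower number from compound 2 to compound 3 (0.79 log units; beyond the scatter), show that moving to 3-(trifluoromethyl)phenyl lowered the number from either methylphenyl analogue, but they give no direct read on chloro at the same place. A step of modest size, or none beyond the scatter, is therefore expected. The expected step from compound 3 to compound 4 is a 1.7-fold higher number from compound 3 to compound 4 (0.22 log units; within the scatter). In this assay compound 4 is estimated at 30000 nM, with a range from 10000 nM to 90000 nM.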

Compound 4, half-maximal inhibitory concentration: 21000 nM
The estimate for compound 4 lay 1.4-fold (0.15 log units) above the measured number; the measured number falls inside the stated range.
By their numbers in this assay, from the lowest: compounds 3 and 4 (each within the scatter of the next); then compound 2; then compound 1.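

In this assay, chloro in place of trifluoromethyl on this aromatic carbon stays within the scatter (a 1.2-fold higher number from compound 3 to compound 4 (0.07 log units; within the scatter)), so a single chlorine and the four heavy atoms of trifluoromethyl are not told apart here. The 3-chlorophenyl analogue also stands clear of both methylphenyl analogues (a 5.2-fold lower number from compound 2 to compound 4 (0.72 log units; beyond the scatter)) (a 13-fold lower number from compound 1 to compound 4 (1.11 log units; beyond the scatter)), so the low number of compound 3 does not depend on trifluoromethyl alone. No measurement at hand accounts for this result.

Going by these compounds, whether these lower numbers follow from the place on the ring or from the groups themselves remains open, and a 3-methylphenyl or an unsubstituted phenyl would separate the two. Also open, on these data alone, is how an amine or a carboxylic acid at this place would read in this assay.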